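A few compounds are considered here, and "the series" means these few. Any claim that something is new, unique, unknown or untested is made for them only; others in the source may bear on it.

Measured so far in a functional assay on HT-29 cells (Homo sapiens) for antiproliferative activity, read by sulforhodamine B assay, with a stated time of 48 h; a higher number here means a weaker inhibitor, a lower number a stronger inhibitor:

Compound 1 `O=C1NCCN1c1ccc(S(=O)(=O)Nc2cccc(Br)c2)cc1`: 77 nM
Compound 2 `O=C1NCCN1c1ccc(S(=O)(=O)Nc2ccc3c(c2)CCC3)cc1`: 190 nM

Two compounds have numbers in this assay . Compound 1 gives 77 nM, the lowest of the two. Compound 2 gives 190 nM, a higher number whose gap to compound 1 lies beyond the usual scatter of repeat measurements. Going by the values given here, the two structures differ in more than one place, so no single-point step between them has been worked out, and nothing can be read from their pair about any one group.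

Compound 3 `COc1cccc(NS(=O)(=O)c2ccc(N3CCNC3=O)cc2)c1` has not yet been measured in this assay . It comes from compound 1 by one change:

methoxy in place of bromo on an aromatic carbon

Among the compounds with values here, nothing measured so far shows what swapping bromo for methoxy at this position does, so no step can be computed from data. The expected step of a 1.6-fold higher number from compound 1 to compound 3 (0.19 log units; within the scatter) is a small move towards a higher number, one that may well stay within the scatter. For compound 3 the estimated value is 120 nM, with a range from 40 nM to 360 nM.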

Compound 3, half-maximal inhibitory concentration: 120 nM
Compound 3: the middle estimate sits on the measured number at the digits printed; low and high end bracket the measured number.
By their numbers in this assay, from the lowest: compounds 1, 3 and 2 (each within the scatter of the next, the first and the last beyond it).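

In this assay, going by these compounds alone, putting methoxy in place of bromo on this aromatic carbon gives a 1.6-fold higher number from compound 1 to compound 3 (0.19 log units; within the scatter), the first comparison here in which two compounds differ in only one place. At this position, then, a single bromine atom can give way to a methoxy group, which has two heavy atoms and brings one hydrogen-bond acceptor, with no difference that can be told apart from the normal variation between repeat measurements. The data at hand offer no explanation for this result.

As far as these compounds go, a single swap cannot show how far this freedom extends, so it remains open whether an amine, a carboxylic acid or a longer chain such as ethoxy at this position would also stay close to compound 1. From the compounds shown here alone, it is equally open whether bromo and methoxy would match each other at another place on the ring, and compound 2 cannot help settle this, as it differs from compound 1 and compound 3 in more than a single group.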